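The source may hold more compounds than are shown below. What is called first, only, known or untested is meant among the compounds shown, and "the series" means these compounds.

In an ADME assay for permeability, using PAMPA, at pH 4 (a higher number here means that the compound crosses the layer faster, a lower number that the compound crosses the layer more slowly), compound 1 `CCCCCCC/C=C/c1c(C)[nH]c2ccccc2c1=O` gives 174 10^-6 cm/s and compound 2 `Cc1[nH]c2ccccc2c(=O)c1/C=C/c1ccccc1` gives 222 10^-6 cm/s. These numbers lie within the scatter of each other, so compound 2 cannot be told apart from compound 1. Compound 3 `Cc1[nH]c2ccccc2c(=O)c1/C=C/c1ccc(O)cc1` carries hydroxy in place of hydrogen on an aromatic carbon of compound 2: hydroxy in place of hydrogen on an aromatic carbon. For the measured compounds named here, the only measured step, a 1.3-fold higher number from compound 1 to compound 2 (0.11 log units; within the scatter), puts phenyl in place of heptyl. Going by the values given here, no measured step adds a hydroxy, so the guidance is weak. The estimated step, a modest fall, is a 1.9-fold lower number from compound 2 to compound 3 (0.27 log units; within the scatter). The expected value for compound 3 is 120 10^-6 cm/s, with an estimated range from 40 10^-6 cm/s to 260 10^-6 cm/s.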

Compound 3, apparent permeability: 10.7 10^-6 cm/s
Compound 3: middle estimate off by 11-fold (1.05 log units), on the high side; the whole stated range lies above it.
By their numbers in this assay, from the lowest: compound 3; then compounds 1 and 2 (each within the scatter of the next).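

In this assay, one hydroxy on the six-membered aromatic ring, para to a large group, gives a 21-fold lower number from compound 2 to compound 3 (1.32 log units; beyond the scatter), whereas phenyl in place of heptyl stayed within the scatter. Putting 4-hydroxyphenyl in place of heptyl gives a 16-fold lower number from compound 1 to compound 3 (1.21 log units; beyond the scatter), so the large fall appears only once the hydroxy is present. Nothing available explains the size of this fall. Going by these compounds, whether a methoxy or an amine at the same place would give a similar fall remains open, as does the outcome for a hydroxy elsewhere on the ring.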